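A few compounds are considered here, and "the series" means these few. Any claim that something is new, unique, unknown or untested is made for them only; others in the source may bear on it.

Compound 1 `CCCn1c(=O)[nH]c2nc(-c3ccc(S(=O)(=O)N4CCN(c5ccccc5C)CC4)cc3)[nH]c2c1=O` gives 0.432 nM in an assay on CHO cells for displacement of a labelled ligand from adenosine receptor A2b (Homo sapiens), read by scintillation counting, with a stated time of 75 min, in the presence of a further agent that is not named here (a lower number here means a stronger inhibitor, a higher number a weaker inhibitor), and compound 2 `CCCn1c(=O)[nH]c2nc(-c3ccc(S(=O)(=O)N4CCN(c5ccc(C)cc5)CC4)cc3)[nH]c2c1=O` gives 0.706 nM in this assay. For the measured compounds named here, the one step between them, a 1.6-fold higher number from compound 1 to compound 2 (0.21 log units; within the scatter), moves the methyl group from the 2-position to the 4-position of the phenyl ring on the amine nitrogen of the piperazine, and the change stays within the scatter. Compound 2 therefore holds the higher of the two numbers seen so far, with compound 1 within the scatter of it; on these two numbers the two cannot be set apart.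

Compound 3 `CCCn1c(=O)[nH]c2nc(-c3ccc(S(=O)(=O)N4CCN(c5ccc(I)cc5)CC4)cc3)[nH]c2c1=O` keeps the shared core of compound 2 and carries the change (iodo in place of methyl on an aromatic carbon), on an aromatic carbon of a six-membered aromatic ring of carbon only, para to a large group. Going by the values given here, no measured step swaps a methyl for an iodo group; the only step known, from compound 1 to compound 2, concerns where a methyl sits and was within the scatter. Among the compounds with values here, with no step bearing directly on the change, compound 3 is expected to land close to compound 2, the step of a 1.2-fold lower number from compound 2 to compound 3 (0.07 log units; within the scatter) being expected to stay within the scatter. For compound 3 the estimate in this assay is 0.6 nM, with a range from 0.2 nM to 2 nM.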

Compound 3, inhibition constant: 0.159 nM
The estimate for compound 3 lay 3.8-fold (0.58 log units) above the measured number, outside the stated range (below it).
By their numbers in this assay, from the lowest: compound 3; then compounds 1 and 2 (each within the scatter of the next).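

The change of group on this aromatic carbon, para to a large group, does what moving the methyl did not: in this assay, iodo in place of methyl gives a 4.4-fold lower number from compound 2 to compound 3 (0.65 log units; beyond the scatter), a modest step but one that lies beyond the scatter, while a 1.6-fold higher number from compound 1 to compound 2 (0.21 log units; within the scatter) stayed within it. The 4-iodophenyl group also separates from the 2-methylphenyl group, with a 2.7-fold lower number from compound 1 to compound 3 (0.43 log units; beyond the scatter), so compound 3 is the strongest inhibitor of the three, whereas the two methyl compounds cannot be told apart. Nothing at hand accounts for this difference between the iodo and methyl compounds.

The compounds shown leave open whether the lower number is particular to iodo or would also appear with another group on this carbon, such as chloro, bromo or methoxy, and whether iodo would give a similar step on the ring carbon that holds the methyl in compound 1. They also leave open whether the step would carry over to a core bearing a longer chain in place of the one shared here.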